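Trifluoromethoxy for trifluoromethyl in the diaryl series

The compounds below may be only part of what the source reports. "The series", "measured", "known", "first", "only" and "open" are said of these compounds alone.

Compound 2 `Oc1cccc(-c2cc(-c3ccccc3C(F)(F)F)cc(-c3ccccc3O)n2)c1` carries a trifluoromethyl group on one of its outer rings and in a functional assay on HCT-15 cells (Homo sapiens) for inhibition (on this read-out lower numbers stand for stronger inhibition and higher numbers for weaker inhibition), gives 9010 nM. Compound 1 `Oc1cccc(-c2cc(-c3ccccc3F)cc(-c3ccccc3O)n2)c1` has a fluoro group at the same place and in this assay gives 8470 nM. Compound 3 `Oc1cccc(-c2cc(-c3cccc(C(F)(F)F)c3)cc(-c3ccccc3O)n2)c1` bears 3-(trifluoromethyl)phenyl in place of 2-fluorophenyl and in this assay gives 6460 nM. Compound 2 shows the highest number of the three, but the steps of a 1.1-fold higher number from compound 1 to compound 2 (0.03 log units; within the scatter) and a 1.4-fold lower number from compound 2 to compound 3 (0.14 log units; within the scatter) are both within the scatter, as is a 1.3-fold lower number from compound 1 to compound 3 (0.12 log units; within the scatter), so no order among the three can be read.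

Compound 4 `Oc1cccc(-c2cc(-c3ccccc3OC(F)(F)F)cc(-c3ccccc3O)n2)c1` differs from compound 2 in one place: trifluoromethoxy in place of trifluoromethyl on an aromatic carbon. For the measured compounds named here, the only steps that bear on it are the changes of the group at that ring position, from fluoro to trifluoromethyl (a 1.1-fold higher number from compound 1 to compound 2 (0.03 log units; within the scatter)) and the move of the trifluoromethyl to another ring position (a 1.4-fold lower number from compound 2 to compound 3 (0.14 log units; within the scatter)), neither of which left the scatter. On that basis no step beyond the scatter is expected in this assay, in either direction. The step of a 1.0-fold lower number from compound 2 to compound 4 (0.00 log units; within the scatter) is the expected outcome. Compound 4 is therefore estimated at 9000 nM in this assay, with a range of 4500 nM to 18000 nM.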

Compound 4, half-maximal inhibitory concentration: 3240 nM
Beside the measured number, compound 4's estimate is 2.8-fold (0.44 log units) above it; measured number below the stated range.
By their numbers in this assay, from the lowest: compounds 4, 3, 1 and 2 (each within the scatter of the next, the first and the last beyond it).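

In this assay this place, ortho to a large group, now proves able to move the read-out: a 2.8-fold lower number from compound 2 to compound 4 (0.44 log units; beyond the scatter) is a modest step, but the first in the series beyond the scatter. The second step, a 2.6-fold lower number from compound 1 to compound 4 (0.42 log units; beyond the scatter), is of similar size and also modest, whereas fluoro and trifluoromethyl at this place could not be told apart, so trifluoromethoxy stands apart from both groups it was compared with here. Nothing available explains this difference.

Open, going by these compounds, is whether the step depends on the fluorines of trifluoromethoxy, which methoxy at the same place would test, and whether a longer chain such as ethoxy or an amine would give a similar number. Also open, on these data alone, is whether trifluoromethoxy would give a similar step at the ring position that carries trifluoromethyl in compound 3.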